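Carbamate oxygen substituent in a fluoropyrimidinone nucleoside series

This account rests on a few compounds, and the source may have more. Where it says the series, first, only, none or still open, it means among the compounds named here.

Measured compounds:
- compound 1, `C[C@H]1O[C@@H](n2cc(F)c(NC(=O)Oc3ccc(Cl)cc3)nc2=O)[C@H](O)[C@@H]1O`: 90 ug/mL
- compound 2, `CCCCCOC(=O)Nc1nc(=O)n([C@@H]2O[C@H](C)[C@H]3OC(=O)O[C@H]32)cc1F`: 180 ug/mL

Both compounds were read in a functional assay on NCI-H69 cells (Homo sapiens) for cytotoxicity, read by MTT assay, with a stated time of 3 days; a higher number here means a weaker inhibitor, a lower number a stronger inhibitor. Compound 1 gives 90 ug/mL, which is the lowest of the two numbers in hand. The nearest number is that of compound 2, and the two values lie within the usual scatter of each other, so no order between compound 1 and compound 2 can be read from them. Going by the values given here, no step between measured compounds that differ in one place is available.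

Compound 3, `CC(C)CCOC(=O)Nc1nc(=O)n([C@@H]2O[C@H](C)[C@@H](O)[C@H]2O)cc1F`, is not yet measured. Relative to compound 1 the difference is isopentyl in place of 4-chlorophenyl on an oxygen next to a carbonyl group. The only point of reference for a chain on that oxygen is compound 2, whose value sits within the scatter of compound 1. On that basis no step beyond the scatter is expected in this assay from compound 1 to compound 3, in either direction. Compound 3 is therefore estimated at 120 ug/mL, with a range from 50 ug/mL to 300 ug/mL, meaning an expected step of a 1.3-fold higher number from compound 1 to compound 3 (0.12 log units; within the scatter).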

Compound 3, half-maximal inhibitory concentration: 370 ug/mL
Estimate against measurement, compound 3: 3.1-fold (0.49 log units) below, and the stated range ends below it.
By their numbers in this assay, from the lowest: compounds 1 and 2 (each within the scatter of the next); then compound 3.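

In this assay, isopentyl in place of 4-chlorophenyl on an oxygen next to a carbonyl group gives a 4.1-fold higher number from compound 1 to compound 3 (0.61 log units; beyond the scatter) on an otherwise unchanged core, so the group on this oxygen does register in the read-out, though the step is modest. The earlier pair could not show this: compound 2 differs from compound 1 in its core as well as in its chain, which left the contribution of the chain unseparated from that of the core, whereas compound 1 and compound 3 differ in this one place only. Nothing in hand bears on what lies behind the step.

On these data alone, the change removes the aromatic ring and the chlorine together, so it remains open which of the two the step follows, and a plain phenyl or a benzyl on the same oxygen would separate them. Also open, as far as these compounds go, is how the read-out responds to chain length on the core of compound 1, where a longer chain such as octyl would extend the comparison beyond isopentyl.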